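This account rests on a few compounds, and the source may have more. Where it says the series, first, only, none or still open, it means among the compounds named here.

Compound 2 `CCC[C@@H](CO)Nc1nc(N)nc(C)c1Cc1ccc(CNCCO)cc1OC` gives 5370 nM in an assay on HEK293 cells for agonist activity at Toll-like receptor 8 (Homo sapiens) (a lower number here means that less compound is needed, a higher number that more compound is needed for the effect), the highest of the two numbers in view. Compound 3 `CCC[C@@H](CO)Nc1nc(N)nc(C)c1Cc1ccc(CNC)cc1OC` gives 2140 nM in this assay, and the step of a 2.5-fold lower number from compound 2 to compound 3 (0.40 log units; beyond the scatter) is the only measured step among these compounds. Compound 1 `CCC[C@@H](CCO)Nc1nc(N)nc(C)c1Cc1ccc(CNC2CN(C)C2)cc1OC` reaches only > 10000 nM in this assay, which is a limit of the assay and not a number.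

Compound 4 `CCC[C@@H](CCO)Nc1nc(N)nc(C)c1Cc1ccc(CNCCO)cc1OC` differs from compound 2 by hydroxymethyl in place of hydroxy on a saturated chain carbon, two bonds along the chain from a nitrogen on an aromatic ring. Among the compounds with values here, no measured step touches this place: the step of a 2.5-fold lower number from compound 2 to compound 3 (0.40 log units; beyond the scatter) concerns a different part of the molecule, the group attached to the amine nitrogen on the aminomethyl arm, so its size offers no direct guide. Within the data shown here, compound 1, the only compound in view that carries the 2-hydroxyethyl chain in place of hydroxymethyl, sits at a limit. A step of a 1.4-fold higher number from compound 2 to compound 4 (0.15 log units; within the scatter) is therefore expected, a modest weakening at most and possibly none beyond the scatter. Compound 4 is accordingly estimated at 7500 nM, within a range from 2500 nM to 22000 nM.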

Compound 4, half-maximal effective concentration: > 10000 nM
Compound 4 ended at the assay's limit (the forecaster's own chance of this, stated with the estimate: 35%); middle value at least 1.3-fold (0.12 log units) away from the limit.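

Extending 1-(hydroxymethyl)butyl to 1-(2-hydroxyethyl)butyl gives the first reading at this position, an at least 1.8-fold higher number from compound 2 to compound 4 (0.27 log units; that floor lies within the scatter), so the floor alone does not establish a loss beyond the scatter. In this assay the two compounds with the 1-(2-hydroxyethyl)butyl group, compound 1 and compound 4, both end at a limit of the assay and not at a number: the limit of > 10000 nM in this assay, at which 2 of the 4 values shown sit.

The step between these two compounds cannot be read, so the change on the amine nitrogen from 1-methylazetidin-3-yl to 2-hydroxyethyl shows no measurable effect here.

From the compounds shown here alone, how far compound 4 lies past its limit remains open, and with it the true size of this step. Also open, going by these compounds, is whether a methoxymethyl group or an aminomethyl group at this place would keep the number of compound 2, and whether the longer chain behaves the same with the methylamino arm of compound 3.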